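Replacing Bromo with Nitro on a Shared Core

The source may hold more compounds than are shown below. What is called first, only, known or untested is meant among the compounds shown, and "the series" means these compounds.

Of the compounds shown here, three built on the same core have been measured in a functional assay on Huh-7 cells (Homo sapiens) for inhibition, read by sulforhodamine B assay, with a stated time of 72 h; on this read-out higher numbers stand for weaker inhibition and lower numbers for stronger inhibition. Compound 1 `CC(c1ccc(-c2ccccc2)c(F)c1)c1nnc2n1N=C(c1ccc(Cl)cc1Cl)CS2` gives 3700 nM. Compound 2 `CC(C)Cc1ccc(C(C)c2nnc3n2N=C(c2ccc(Br)cc2)CS3)cc1` gives 4900 nM. Compound 3 `CC(c1ccc(-c2ccccc2)c(F)c1)c1nnc2n1N=C(c1ccc(F)cc1)CS2` gives 4900 nM. Going by the values given here, the one single-point comparison among them, a 1.3-fold higher number from compound 1 to compound 3 (0.12 log units; within the scatter), changes the aryl group on the carbon with a double bond to nitrogen and stays within the scatter. Compound 2 stands level with compound 3 at the digits shown, the two together the highest numbers of the three, and its difference from compound 1 is also within the scatter, so the three compounds cannot be ranked.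

Compound 4 `CC(C)Cc1ccc(C(C)c2nnc3n2N=C(c2ccc([N+](=O)[O-])cc2)CS3)cc1` differs from compound 2 in one place: nitro in place of bromo on an aromatic carbon. Among the compounds with values here, the only measured step that bears on this change is the one from compound 1 to compound 3, which alters the same aryl group and moved the number by a 1.3-fold higher number from compound 1 to compound 3 (0.12 log units; within the scatter), a size within the scatter. With that single precedent, no step beyond the scatter is expected in this assay in either direction. Compound 4 is therefore estimated at 5000 nM, within a range of 2000 nM to 14000 nM. The expected step from compound 2 to compound 4 is a 1.0-fold higher number from compound 2 to compound 4 (0.01 log units; within the scatter).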

Compound 4, half-maximal inhibitory concentration: "not active" (no number reported)
Nothing numeric was reported for compound 4; the estimate stays without a comparison.
By their numbers in this assay, from the lowest: compounds 1, 2 and 3 (each within the scatter of the next).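

Going by these compounds alone, compound 4 is reported as "not active" in this assay without a number, so no step from compound 2 to compound 4 can be read. Nothing shown here accounts for this result. The compounds shown leave open how far 4-nitrophenyl in place of 4-bromophenyl moves the number on this read-out.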